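This account rests on a few compounds, and the source may have more. Where it says the series, first, only, none or still open, it means among the compounds named here.

Measured so far in an assay on HEK293 cells for displacement of a labelled ligand from metabotropic glutamate receptor 5 (Homo sapiens), with a stated time of 2 h; on this read-out lower numbers stand for stronger inhibition and higher numbers for weaker inhibition:
compound 1, `Cc1ccc(C#Cc2ccc3c(n2)CCN(C)C3=O)cc1`: 7450 nM
compound 2, `CC(C)N1CCc2nc(C#Cc3cccc(Cl)c3)ccc2C1=O`: 100 nM
compound 3, `Cc1ccc(C#Cc2ccc3c(n2)CCN(C2CCCC2)C3=O)cc1`: > 32000 nM, which is a limit of the assay and not a number

Compound 3 stands at the limit of > 32000 nM in this assay, at which 1 of the 3 values shown sits; nothing better than that limit is known for it, so it sits at the weak end of what has been measured. Among the compounds with values here, the only step that reaches compound 3 is an at least 4.2-fold higher number from compound 1 to compound 3 (0.63 log units; beyond the scatter), already beyond the scatter, though its size is known only as a floor. Within the data shown here, compound 2 differs from compound 1 in two places at once, so no single step links them; their two values simply show that a different aryl group together with a different amide substituent goes with a far lower number.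

Compound 4, `O=C1c2ccc(C#Cc3cccs3)nc2CCN1C1CCCC1`, keeps the cyclopentyl of compound 3 and alters the aryl end: thiophen-2-yl in place of 4-methylphenyl on a triple-bonded carbon. Among the measured compounds shown here, no measured step touches this position in the present set, so nothing here sizes the change; the cyclopentyl that drove compound 3 to its limit remains. Compound 4 is therefore expected to stay weak in this assay, with a step of an at least 2.1-fold lower number from compound 3 to compound 4 (0.32 log units; beyond the scatter) at most modest and uncertain in direction. The estimate for compound 4 is 15000 nM, within 3000 nM to 64000 nM, with a real chance that only a limit is reported again.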

Compound 4, inhibition constant: 2840 nM
Compound 4: middle estimate off by 5.3-fold (0.72 log units), on the high side; the whole stated range lies above it.
By their numbers in this assay, from the lowest: compound 2; then compound 4; then compound 1. At a limit, above all of these: compound 3.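

Thiophen-2-yl in place of 4-methylphenyl on a triple-bonded carbon gives, in this assay, an at least 11-fold lower number from compound 3 to compound 4 (1.05 log units; beyond the scatter), the only single-place step at this position among the compounds shown, and it is large. With cyclopentyl held on the amide-type nitrogen, the aryl end alone moves the read-out this far, so cyclopentyl does not by itself fix a compound at the weak end, a possibility that the earlier step from methyl to cyclopentyl had left standing. For compound 3 the value is a limit and not a number, so the size of this step is only a floor: the limit of > 32000 nM in this assay, at which 1 of the 4 values shown sits.

The compounds shown leave open whether thiophen-2-yl brings a similar change with methyl or isopropyl on the amide-type nitrogen, since the one step at this position has cyclopentyl there. They also leave open whether the change follows the sulfur-containing five-membered ring in particular, which a furan-2-yl, a thiophen-3-yl or a pyridin-2-yl group at the same place on the cyclopentyl compound would help to separate.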